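Hydroxymethyl in Place of the Amine on the Cyclohexyl

This account rests on a few compounds, and the source may have more. Where it says the series, first, only, none or still open, it means among the compounds named here.

Compound 1 `Nc1ncnc2c1c(Oc1cc(C(F)(F)F)ccn1)nn2[C@H]1CC[C@@H](N)CC1` was examined in an ADME assay on microsomes from liver (Mus musculus) for metabolic stability, read by LC-MS, using NADPH, with a stated time of 10 min, tested at 10 uM; a higher number here means that the compound lasts longer, a lower number that the compound disappears faster. Within the data shown here, only two compounds have numbers: in this assay compound 1 gives 0.917 h, and compound 2 `CC(C)(C)n1nc(Oc2cc(C#N)ccn2)c2c(N)ncnc21` gives 0.767 h, a value that sits within the usual scatter of that of compound 1. Compound 3 `Nc1ncnc2c1c(Oc1cc(C(F)(F)F)ccn1)nn2[C@H]1CC[C@H](CO)CC1` differs from compound 1 in a single place: 4-(hydroxymethyl)cyclohexyl in place of 4-aminocyclohexyl on an aromatic nitrogen. Among the measured compounds shown here, no measured pair covers this change, so its size is not known from the data. The expected step of a 1.3-fold lower number from compound 1 to compound 3 (0.12 log units; within the scatter) is small and downward, not clearly beyond the scatter. Compound 3 is estimated to give 0.7 h, with a range from 0.35 h to 1.4 h.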

Compound 3, half-life: 0.383 h
Beside the measured number, compound 3's estimate is 1.8-fold (0.26 log units) above it; low and high end bracket the measured number.
By their numbers in this assay, from the lowest: compounds 3, 2 and 1 (each within the scatter of the next, the first and the last beyond it).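

The group on the aromatic nitrogen matters in this assay: 4-(hydroxymethyl)cyclohexyl in place of 4-aminocyclohexyl gives a 2.4-fold lower number from compound 1 to compound 3 (0.38 log units; beyond the scatter) and this modest step lies beyond the scatter. The ring and the counted donor and acceptor stay the same across the change, so those counts alone do not fix the half-life here. Nothing at hand gives a reason for this step. From the compounds shown here alone, whether it follows from losing the amine or from the added carbon stays open. An aminomethyl group or a plain hydroxyl on the cyclohexyl would separate the two.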